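Two Measured Compounds and an Expectation for a Third

This account rests on a few compounds, and the source may have more. Where it says the series, first, only, none or still open, it means among the compounds named here.

Compound 1 `O=C(Nc1ccc(-n2ccccc2=O)cn1)[C@H]1C[C@](O)(c2ccccc2)CN1C(=O)Nc1ccc(Cl)cc1` gives 2.9 h in an in vivo ADME assay on the whole organism for metabolic stability, with Canis familiaris (Canis lupus familiaris) as the target, using cassette dosing; a higher number here means that the compound lasts longer, a lower number that the compound disappears faster.
Compound 2 `O=C(Nc1ccc(-n2ccccc2=O)cn1)[C@H]1C[C@](O)(c2ccccc2Cl)CN1C(=O)Nc1ccc(Cl)cc1` gives 0.8 h in this assay.

Within the data shown here, compound 2 has the lower of the two numbers; compound 1 is its only neighbour, and the step is a 3.6-fold lower number from compound 1 to compound 2 (0.56 log units; beyond the scatter). Compound 3 `O=C(Nc1ccc(-n2ccccc2=O)cn1)[C@H]1C[C@](O)(c2ccc(F)c(F)c2)CN1C(=O)Nc1ccc(Cl)cc1` differs from compound 2 by 3,4-difluorophenyl in place of 2-chlorophenyl on a saturated ring carbon. Among the measured compounds shown here, the step from compound 1 to compound 2 bears on this change only in part: it shows what a chloro in place of hydrogen did, but no measured pair shows what two fluorines do. With the chlorine gone, compound 3 is expected to recover some of that loss, giving a 1.9-fold higher number from compound 2 to compound 3 (0.27 log units; within the scatter). The estimate for compound 3 is 1.5 h, ranging from 0.6 h to 4 h.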

Compound 3, half-life: 2.1 h
Beside the measured number, compound 3's estimate is 1.4-fold (0.15 log units) below it; low and high end bracket the measured number.
By their numbers in this assay, from the lowest: compound 2; then compounds 3 and 1 (each within the scatter of the next).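

At this saturated ring carbon, a substituted phenyl does not have to bring a short half-life: 3,4-difluorophenyl in place of 2-chlorophenyl gives a 2.6-fold higher number from compound 2 to compound 3 (0.42 log units; beyond the scatter) and so reverses most of the earlier loss. Set against plain phenyl, the difluorinated ring gives a 1.4-fold lower number from compound 1 to compound 3 (0.14 log units; within the scatter) and so cannot be told apart from it. Nothing measured here explains the difference between the two substituted rings.

Still open, from the compounds shown here alone, is whether the loss follows the chlorine itself or its place on the ring. Also open, going by these compounds, is how a methoxy group or an amine on this phenyl ring would fare.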